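Isopropyl in place of phenyl in compound 2

The compounds below may be only part of what the source reports. "The series", "measured", "known", "first", "only" and "open" are said of these compounds alone.

In a physicochemical assay for lipophilicity, read by HPLC, at pH 7.4 (on this read-out lower numbers stand for lower lipophilicity and higher numbers for higher lipophilicity), compound 1 (`O=C1CN(Cc2ccc(-c3ccc(C4(C(=O)O)CC4)cc3)cc2)C(=O)N1c1ccccc1`) stands lowest at 1.5 and compound 3 (`O=C1CN(Cc2ccc(-c3ccccc3)cc2)C(=O)N1c1ccccc1`) highest at 6.24 of the three measured, with compound 2 (`O=C(O)Cc1ccc(-c2ccc(CN3CC(=O)N(c4ccccc4)C3=O)cc2)cc1`) second highest at 2.18 in this set. Compound 4 (`CC(C)N1C(=O)CN(Cc2ccc(-c3ccc(CC(=O)O)cc3)cc2)C1=O`) differs from compound 2 by isopropyl in place of phenyl on an amide-type nitrogen in a ring.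

For the measured compounds named here, no measured step touches this nitrogen. All three lie on an aromatic carbon, so they serve only as a guide to size. Hydrogen in place of carboxymethyl gives the large a number 4.06 log units higher from compound 2 to compound 3 (beyond the scatter) and hydrogen in place of 1-carboxycyclopropyl gives the large a number 4.74 log units higher from compound 1 to compound 3 (beyond the scatter) in this series. Compound 4 keeps the carboxymethyl of compound 2, so the closer guide is the modest a number 0.68 log units higher from compound 1 to compound 2 (beyond the scatter) between two compounds that both carry a carboxylic side group.

With the phenyl ring gone and carbon atoms lost, a modest step downward in this assay is expected, probably beyond the scatter. The expected size is a number 0.68 log units lower from compound 2 to compound 4 (beyond the scatter) as an estimate. For compound 4 the estimated value is 1.5 with an expected range from 0.9 to 2.1 as its ends.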

Compound 4, distribution coefficient: 1.1
Compound 4: the middle estimate sits 0.40 log units above what was measured; the measured number falls inside the stated range.
By their numbers in this assay, from the lowest: compound 4; then compound 1; then compound 2; then compound 3.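

In this assay, the group on the amide-type nitrogen in a ring proves able to move the read-out: isopropyl in place of phenyl gives a number 1.08 log units lower from compound 2 to compound 4 (beyond the scatter), the only step shown at this position. The carboxymethyl stays in place across this pair, so the number still shifts beyond the scatter with the carboxylic side group unchanged, and this step is not as large as a number 4.06 log units higher from compound 2 to compound 3 (beyond the scatter), where that side group is lost. The change swaps one six-membered aromatic ring of carbon only for an open group of fewer carbon atoms, and this single pair cannot separate the loss of the ring from the loss of carbon atoms; nothing shown bears on the reason for the step.

With only phenyl and isopropyl on this nitrogen, the compounds shown leave open where a methyl, a cyclohexyl or a longer chain ending in an amine would fall on this read-out. Also open, going by these compounds, is whether isopropyl in place of phenyl gives a step of similar size when the 1-carboxycyclopropyl of compound 1 replaces the carboxymethyl.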